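This account rests on a few compounds, and the source may have more. Where it says the series, first, only, none or still open, it means among the compounds named here.

In an ADME assay on MDCK cells (Canis lupus familiaris) for cytotoxicity, read by MTT assay, with a stated time of 3 days (a lower number here means that less compound is tolerated, a higher number that more compound is tolerated), three compounds have so far been measured. Compound 1 `CC1(C)C[C@H](O)C[C@](C)(CNc2ccccc2Cl)C1` gives 6900 nM. Compound 2 `CC1(C)C[C@H](O)C[C@](C)(CNc2ccccc2C(F)(F)F)C1` shares its core and differs from it in one place, (trifluoromethyl in place of chloro on an aromatic carbon); in this assay compound 2 gives 6600 nM, so the change made a 1.0-fold lower number from compound 1 to compound 2 (0.02 log units; within the scatter). Compound 3 `CC1(C)C[C@H](O)C[C@](C)(CNc2cc(Cl)cc(S(N)(=O)=O)c2)C1` gives 8400 nM in this assay. Its reading lies within the scatter of those of compound 1 and compound 2, so no order among the three can be drawn, and none of them can be called more or less tolerated than another. The difference between the core of compound 3 and the core of compound 1 is not broken down here.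

Compound 4 `CC1(C)C[C@H](O)C[C@](C)(CNc2cc(C(F)(F)F)cc(S(N)(=O)=O)c2)C1` has not yet been measured in this assay. It differs from compound 3 by trifluoromethyl in place of chloro on an aromatic carbon. This is the same kind of change as that from compound 1 to compound 2, but not the same: in compound 2 the trifluoromethyl stands ortho to a large group, whereas in compound 4 it stands meta to a large group and meta to a sulfamoyl group. The expected step for compound 4 is a 1.0-fold lower number from compound 3 to compound 4 (0.01 log units; within the scatter), because the same exchange earlier gave a 1.0-fold lower number from compound 1 to compound 2 (0.02 log units; within the scatter), a step within the scatter. Compound 4 is therefore estimated at 8200 nM in this assay, expected to fall between 4200 nM and 16000 nM.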

Compound 4, half-maximal cytotoxic concentration: 19500 nM
Estimate against measurement, compound 4: 2.4-fold (0.38 log units) below; the whole stated range lies below it.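

In this assay, trifluoromethyl in place of chloro on an aromatic carbon gave a 2.3-fold higher number from compound 3 to compound 4 (0.37 log units; beyond the scatter), a modest step, so on the core of compound 3 this exchange goes with more compound being tolerated, whereas the same exchange on the core of compound 1 left no reading beyond the scatter. Set side by side, however, the two steps cannot be told apart: the same change on two cores in this assay, a 1.0-fold lower number (0.02 log units; within the scatter) from compound 1 to compound 2 and a 2.3-fold higher number (0.37 log units; beyond the scatter) from compound 3 to compound 4, 2.4-fold (0.39 log units) apart, within the scatter of two such steps. The series therefore shows neither that the core changes the effect of this exchange nor that the effect carries over from one core to the other at a fixed size, and a single pair on each core cannot settle the question either way.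

The compounds shown leave open whether a bromo, a methyl or a nitrile on the same aromatic carbon would read like chloro or like trifluoromethyl on either core. They also leave open whether the step seen from compound 3 to compound 4 depends on the sulfamoyl group, which could be tested by repeating the exchange with a carboxylic acid or a methyl sulfone in its place.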